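The source may report more compounds than this note shows. Statements on the series, on what has been measured and on what is new or still open speak of the compounds shown alone.

In a functional assay on A549 cells (Homo sapiens) for antiproliferative activity, read by WST assay, with a stated time of 72 h (a lower number here means that less compound is needed, a higher number that more compound is needed for the effect), compound 3 `CCCCNCCCC(=O)Nc1ccc(/C(N)=N/O)cc1` gives > 1000000 nM, which is a limit and not a number; it stands at the limit of > 1000000 nM in this assay, at which 2 of the 3 values shown sit. Compound 1 `CCCCCCNCCCC(=O)Nc1ccc(/C(N)=N/O)cc1` gives > 1000000 nM, also a limit. Compound 2 `CCCCNCC(=O)Nc1ccc(/C(N)=N/O)cc1` gives a measured 395000 nM. Compound 4 `CCCCCCNCCC(=O)Nc1ccc(/C(N)=N/O)cc1` carries hexylamino in place of (butylamino)methyl on a saturated chain carbon, two bonds along the chain from a carbonyl carbon. Among the measured compounds shown here, two measured steps bear on this change. Putting 2-(butylamino)ethyl in place of butylamino gives an at least 2.5-fold higher number from compound 2 to compound 3 (0.40 log units; beyond the scatter), and compound 4 partly reverses that lengthening. Hydrogen in place of ethyl gives a step that the two limits leave unreadable from compound 1 to compound 3, so the longer hexyl end offers no guidance. A modest move towards a lower number in this assay is therefore expected, written as an at least 1.6-fold lower number from compound 3 to compound 4 (0.22 log units; that floor lies within the scatter), although the result may again be only a limit. For compound 4 the estimated value is 600000 nM, with an expected range of 250000 nM to 1000000 nM.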

Compound 4, half-maximal effective concentration: > 1000000 nM
Compound 4: no number, only a limit; the forecaster's own chance of this, stated with the estimate: 50%; middle value at least 1.6-fold (0.22 log units) away from the limit.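

Among the compounds shown here, compound 3 and compound 4 both give only a limit and not a number, so no step between them can be read: the limit of > 1000000 nM in this assay, at which 3 of the 4 values shown sit. The compounds shown leave open whether hexylamino in place of (butylamino)methyl changes the needed concentration at all.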